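Dimethoxyphenyl swap at the limit of the assay

The source may report more compounds than this note shows. Statements on the series, on what has been measured and on what is new or still open speak of the compounds shown alone.

Measured in a functional assay on MGC-803 cells (Homo sapiens) for cytotoxicity, read by MTT assay, with a stated time of 72 h; a higher number here means a weaker inhibitor, a lower number a stronger inhibitor:
compound 1 `CN(C)c1ccc(C=C2C(=O)N(c3ccc(Cl)cc3)N(c3ccc(Cl)cc3)C2=O)cc1` gives 80200 nM
compound 2 `COc1ccc(C=C2C(=O)N(c3ccc(Cl)cc3)N(c3ccc(Cl)cc3)C2=O)cc1` gives > 128000 nM (a limit of the assay, not a number)

Compound 2 stands only at a limit, > 128000 nM, so its true position is not known. Compound 3 `COc1cccc(C=C2C(=O)N(c3ccc(Cl)cc3)N(c3ccc(Cl)cc3)C2=O)c1OC` carries 2,3-dimethoxyphenyl in place of 4-methoxyphenyl on a double-bonded chain carbon bound to a double-bonded ring carbon. Within the data shown here, one measured step bears on this change, as it also alters the group on that phenyl ring: an at least 1.5-fold higher number from compound 1 to compound 2 (0.20 log units; that floor lies within the scatter). That step gives a floor and no full size, so it offers little guidance. Among the measured compounds shown here, compound 1 at 80200 nM is the only number, and it suggests that this group can be varied without leaving the weak end of the range. No step beyond the scatter is therefore expected in this assay, and no direction can be favoured with confidence. The expected change is an at least 1.2-fold lower number from compound 2 to compound 3 (0.10 log units; that floor lies within the scatter). For compound 3 the estimated value is 100000 nM, with an expected range of 40000 nM to 180000 nM.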

Compound 3, half-maximal inhibitory concentration: 29600 nM
Compound 3: the middle estimate sits 3.4-fold (0.53 log units) above what was measured, and the stated range ends above it.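

In this assay, the group on a double-bonded chain carbon bound to a double-bonded ring carbon can move the read-out beyond the scatter, which the earlier floor could not show: 2,3-dimethoxyphenyl in place of 4-(dimethylamino)phenyl gives a 2.7-fold lower number from compound 1 to compound 3 (0.43 log units; beyond the scatter). In place of 4-methoxyphenyl the same group gives an at least 4.3-fold lower number from compound 2 to compound 3 (0.63 log units; beyond the scatter), and this size is only a floor because compound 2 has a limit and no number: the limit of > 128000 nM in this assay, at which 1 of the 3 values shown sits.
With both steps beyond the scatter, compound 3 is the strongest of the three compounds at 29600 nM, so a dimethoxy pattern on this phenyl ring does better here than either single substituent shown, although the series has not left the weak end of the range.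

The compounds shown leave open whether the gain belongs to the extra methoxy group or to where the two methoxy groups sit, since 2,3-dimethoxyphenyl differs from 4-methoxyphenyl in both respects. Also open, from the compounds shown here alone, is how a phenyl ring carrying a hydroxy group or a carboxylic acid would read in this assay, and whether any change on this ring can bring the shared core out of the weak range.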